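What a fluoro group may do to compound 2

This account rests on a few compounds, and the source may have more. Where it says the series, first, only, none or still open, it means among the compounds named here.

Compound 1 `CC(C)CN1C(=O)CN(Cc2ccc(-c3ccc(F)c(CN4CCCC(C)C4)n3)cc2)C1=O`: 8.4
Compound 2 `CCN1C(=O)CN(Cc2ccc(-c3cccc(CN4CCCCC4)n3)cc2)C1=O`: 8.8
Compound 3 `CC(C)CN1C(=O)CN(Cc2ccc(-c3ccc(F)c(CN4CCCCC4)n3)cc2)C1=O`: 8.6

These values come from a physicochemical assay for acid dissociation. Compound 2, at 8.8, lies within the usual scatter of compound 3 and beyond the scatter above compound 1.

Compound 4 `CCN1C(=O)CN(Cc2ccc(-c3ccc(F)c(CN4CCCCC4)n3)cc2)C1=O` has one structural change from compound 2: fluoro in place of hydrogen on an aromatic carbon. In words, this is fluoro in place of hydrogen on an aromatic carbon.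

For the measured compounds named here, the single measured step, a number 0.20 log units higher from compound 1 to compound 3 (within the scatter), is a hydrogen in place of methyl on a saturated ring carbon, so it bears only loosely on this change. Going by the values given here, no measured pair isolates the fluoro group. The nearest guide is compound 3, at 8.6, which carries the same fluoro group and has isobutyl where compound 4 has ethyl. A small downward step, not beyond the scatter, is therefore expected in this assay.

The expected change is a number 0.20 log units lower from compound 2 to compound 4 (within the scatter). For compound 4, the estimated value is 8.6, with an expected range from 8.3 to 8.9.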

Compound 4, acid dissociation constant: 8.5
Compound 4: middle estimate off by 0.10 log units, on the high side, and the stated range covers the measured number.
By their numbers in this assay, from the lowest: compounds 1, 4, 3 and 2 (each within the scatter of the next, the first and the last beyond it).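

In this assay, the change from hydrogen to fluoro on an aromatic carbon, two atoms from the ring nitrogen and ortho to the (piperidin-1-yl)methyl group, can now be read directly from a single pair (a number 0.30 log units lower from compound 2 to compound 4 (within the scatter)). With the fluoro group present, compound 3 and compound 4 differ only in the isobutyl or ethyl chain on the amide-type nitrogen, and that chain makes no difference beyond the scatter (a number 0.10 log units lower from compound 3 to compound 4 (within the scatter)). Nothing available here explains these numbers.

Going by these compounds, it remains open whether chloro or methoxy on this same aromatic carbon would give a similar number, or whether fluoro on another carbon of that ring would. On these data alone, the effect of a (morpholin-4-yl)methyl group in place of the (piperidin-1-yl)methyl group also remains open.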